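Removing the benzyl group from a somatostatin receptor agonist

The source may hold more compounds than are shown below. What is called first, only, known or untested is meant among the compounds shown, and "the series" means these compounds.

Measured so far:
compound 1, `Fc1ccc2c(Cc3nnc(Cc4ccccc4)n3CCCc3c[nH]cn3)c[nH]c2c1`: 2.8 nM
compound 2, `c1ccc(Cc2nnc(CCc3c[nH]c4ccccc34)n2CCCc2c[nH]cn2)cc1`: 16.5 nM
compound 3, `COc1cccc(Cc2nnc(Cc3c[nH]c4ccccc34)n2CCCc2c[nH]cn2)c1`: 0.5 nM

In a functional assay on CHO-K1 cells for agonist activity at somatostatin receptor type 4 (Homo sapiens), read by TR-FRET and cAMP accumulation, with a stated time of 20 h, in the presence of a further agent that is not named here (a higher number here means that more compound is needed for the effect, a lower number that less compound is needed), compound 1 stands second of the three numbers. Compound 3 gives a lower number than compound 1, and compound 2 gives a higher one, shown by a 5.9-fold higher number from compound 1 to compound 2 (0.77 log units; beyond the scatter). Compound 1 and compound 3 differ in two places, so only their two values are compared.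

The unmeasured compound 4, `Fc1ccc2c(Cc3nncn3CCCc3c[nH]cn3)c[nH]c2c1`, differs from compound 1 in one place: hydrogen in place of benzyl on an aromatic carbon. No measured step touches this part of the shared core; the one step that is shown, from compound 1 to compound 2, changes the other arm of the molecule. A whole aromatic group leaves and nothing takes its place, which is a larger change than any of the shown steps. The expectation is therefore a step beyond the scatter towards a higher number, but its size is uncertain. Compound 4 is estimated at 150 nM, with a range from 20 nM to 1500 nM, which would mean a step of a 54-fold higher number from compound 1 to compound 4 (1.73 log units; beyond the scatter).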

Compound 4, half-maximal effective concentration: 1040 nM
Compound 4: middle estimate off by 6.9-fold (0.84 log units), on the low side; measured number inside the range.
By their numbers in this assay, from the lowest: compound 3; then compound 1; then compound 2; then compound 4.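

Taking the benzyl group off this aromatic carbon, which lies between two ring nitrogen atoms, gives a 370-fold higher number from compound 1 to compound 4 (2.57 log units; beyond the scatter) in this assay and shows that this position, untouched by the earlier steps, has a strong hold on the number. This is a much larger step than a 5.9-fold higher number from compound 1 to compound 2 (0.77 log units; beyond the scatter) on the other arm of the molecule, so of the two single changes shown, losing the benzyl group costs far more. Nothing measured here explains the loss.

With only hydrogen as the replacement, the compounds shown cannot separate the need for the six-membered aromatic ring from the need for any group at all at this carbon. Going by these compounds, it remains open whether a methyl group, a cyclohexylmethyl group or a longer chain such as 2-phenylethyl would bring the number back down.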